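The source may report more compounds than this note shows. Statements on the series, on what has been measured and on what is new or still open speak of the compounds shown alone.

Compound 1 `COc1ccc(C2CC(c3ccccc3)=NN2C2=NC(=O)/C(=C3\C(=O)Nc4ccccc43)S2)cc1`: 19000 nM
Compound 2 `COc1ccc(C2=NN(C3=NC(=O)/C(=C4\C(=O)Nc5ccccc54)S3)C(c3ccc(OC)cc3)C2)cc1`: 100000 nM

Compound 2 gives the highest of the two numbers in a functional assay on cells (Cancer cell lines, Homo sapiens) for cytotoxicity, read by sulforhodamine B assay, with a stated time of 48 h; a higher number here means a weaker inhibitor of growth, a lower number a stronger inhibitor of growth; its nearest neighbour is compound 1, which gives 19000 nM. Compound 3 `COc1ccc(C2CC(c3ccc4ccccc4c3)=NN2C2=NC(=O)/C(=C3\C(=O)Nc4ccccc43)S2)cc1` differs from compound 2 by naphthalen-2-yl in place of 4-methoxyphenyl on a carbon with a double bond to nitrogen. For the measured compounds named here, the only measured step that bears on this change is a 5.3-fold higher number from compound 1 to compound 2 (0.72 log units; beyond the scatter); compound 3 removes that methoxy again while adding a fused ring, for which no step is known. The expected step is therefore a 4.0-fold lower number from compound 2 to compound 3 (0.60 log units; beyond the scatter), towards lower numbers. Compound 3 is expected to give about 25000 nM, estimated between 8000 nM and 80000 nM.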

Compound 3, concentration for total growth inhibition: 24200 nM
Beside the measured number, compound 3's estimate is 1.0-fold (0.01 log units) above it, within the range that was stated.
By their numbers in this assay, from the lowest: compounds 1 and 3 (each within the scatter of the next); then compound 2.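

At the carbon with a double bond to nitrogen, this assay gives a 4.1-fold lower number from compound 2 to compound 3 (0.62 log units; beyond the scatter) when naphthalen-2-yl replaces 4-methoxyphenyl, yet a 1.3-fold higher number from compound 1 to compound 3 (0.11 log units; within the scatter) when it replaces phenyl. Phenyl and naphthalen-2-yl therefore cannot be told apart here, and among these three groups only 4-methoxyphenyl stands apart. Nothing available gives a reason for these numbers. Still open, as far as these compounds go, is how an amine, a carboxylic acid or a longer chain at this carbon would read. Also open, from the compounds shown here alone, is whether any group here can bring the number far lower.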